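A few compounds are considered here, and "the series" means these few. Any claim that something is new, unique, unknown or untested is made for them only; others in the source may bear on it.

Compound 1 `COc1cc2nc(N3CCC(OCCOC(C)C)CC3)nc(N)c2cc1OC`: 0.67 nM
Compound 2 `COc1cc2nc(N3CCC(OCCOc4ccccc4)CC3)nc(N)c2cc1OC`: 0.48 nM

Both measured compounds share the same core and differ only in the group attached to an oxygen on a saturated carbon. In an assay on brain for displacement of a labelled ligand from Adrenergic receptor alpha-1 (Rattus norvegicus) (on this read-out lower numbers stand for stronger inhibition and higher numbers for weaker inhibition), compound 2 gives 0.48 nM, the lower of the two numbers, while compound 1 gives 0.67 nM. The step between them, a 1.4-fold lower number from compound 1 to compound 2 (0.14 log units; within the scatter), is within the usual scatter, so the two compounds cannot be told apart on these data.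

Compound 3 `COc1cc2nc(N3CCC(OCC(C)(C)OC)CC3)nc(N)c2cc1OC` has not yet been measured. It differs from compound 2 in one place: 1-methoxy-1-methylethyl in place of phenoxymethyl on a saturated chain carbon bound to an oxygen on a saturated carbon. Among the compounds with values here, only one measured step bears on this change: a 1.4-fold lower number from compound 1 to compound 2 (0.14 log units; within the scatter), which exchanged one small alkyl group for a phenyl at the same oxygen and stayed within the scatter. Returning from the phenyl-bearing chain to a small alkyl ether chain is therefore expected to move the number little, if at all. Compound 3 is expected to show a 1.7-fold higher number from compound 2 to compound 3 (0.22 log units; within the scatter) in this assay because a 1.4-fold lower number from compound 1 to compound 2 (0.14 log units; within the scatter) was within the scatter. The estimate for compound 3 is 0.8 nM, with a range from 0.3 nM to 2 nM.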

Compound 3, inhibition constant: 1.14 nM
For compound 3 the middle estimate is 1.4-fold (0.15 log units) below the measured one; the range from low to high includes it.
By their numbers in this assay, from the lowest: compounds 2, 1 and 3 (each within the scatter of the next, the first and the last beyond it).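

In this assay, within the data shown here, putting 1-methoxy-1-methylethyl in place of phenoxymethyl gives the first step at this place that lies beyond the scatter, with a 2.4-fold higher number from compound 2 to compound 3 (0.38 log units; beyond the scatter) as a modest change, so the group carried here does register in this read-out. Set against the isopropoxymethyl of compound 1, the same group gives a 1.7-fold higher number from compound 1 to compound 3 (0.23 log units; within the scatter) and stays within the scatter, and compound 1 also lies within the scatter of compound 2, so this series does not split cleanly into chains with the aromatic ring and chains without it. Nothing measured here gives a reason for these steps.

The change to compound 3 removes the phenyl ring and adds branching on the chain in a single exchange, so the compounds shown cannot say which of the two matters for the step. Also open is how this assay would respond to an amine or a carboxylic acid at the end of the chain, or to a longer chain, since every group shown here is a neutral ether.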